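This account rests on a few compounds, and the source may have more. Where it says the series, first, only, none or still open, it means among the compounds named here.

Measured in a functional assay on HEK293 cells (Homo sapiens) for cytotoxicity; on this read-out lower numbers stand for higher toxicity in this test and higher numbers for lower toxicity in this test:
- compound 1 `COc1ccc([C@H]2CC(=O)N(c3cccc(O)c3)C2)cc1OC1CCCC1` gives > 10000 nM as a limit
- compound 2 `COc1ccc([C@H]2CC(=O)N(c3ccc(N)cc3)C2)cc1OC1CCCC1` gives > 10000 nM as a limit
- compound 3 `COc1ccc([C@H]2CC(=O)N(c3ccc(C)cc3)C2)cc1OC1CCCC1` gives > 10000 nM as a limit

Compound 3 thus stands at a limit and not at a number, and the other two compounds stand there with it. The next compound is compound 4 `COc1ccc([C@H]2CC(=O)N(c3cccnc3)C2)cc1OC1CCCC1`, which carries pyridin-3-yl in place of 4-methylphenyl on an amide-type nitrogen in a ring. The counted difference is pyridin-3-yl in place of 4-methylphenyl on an amide-type nitrogen in a ring and it leaves the rest of the shared core untouched.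

Three measured steps change the same place or the group on it: a step that the two limits leave unreadable from compound 1 to compound 3, a step that the two limits leave unreadable from compound 2 to compound 3 and a step that the two limits leave unreadable from compound 1 to compound 2. No size can be read from them because the limit of > 10000 nM in this assay, at which 3 of the 3 values shown sit, sets all three compounds at the same limit. No change measured at that place has yet given a number in this assay, so no direction can be taken from them. A step beyond the usual scatter is therefore not expected, and the estimated step is a step that the limit leaves unreadable from compound 3 to compound 4 in this read-out.

For compound 4 the expected value is 20000 nM, with an estimated range from 8000 nM to 50000 nM, and a report of only a limit is the likeliest outcome.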

Compound 4, half-maximal cytotoxic concentration: > 10000 nM
Compound 4: no number, only a limit; the forecaster's own chance of this, stated with the estimate: 90%; the middle value lies beyond the limit too.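

In this assay compound 4 gives > 10000 nM as a limit and not a number. Among these compounds, no step among compound 1, compound 2, compound 3 and compound 4 can be read, because all four stand at the same limit: the limit of > 10000 nM in this assay, at which 4 of the 4 values shown sit. The compounds shown leave open whether any group on the amide-type nitrogen gives a number in this assay at all.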